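Pyrimidin-2-yl in place of a cyanofuran on the core

A few compounds are considered here, and "the series" means these few. Any claim that something is new, unique, unknown or untested is made for them only; others in the source may bear on it.

Compound 2 `N#Cc1ccc(-c2nc(N)c3cc(Cc4ccccc4)sc3n2)o1` was examined in a functional assay on CHO-K1 cells for antagonist activity at adenosine receptor A1 (Homo sapiens), read by a beta-galactosidase reporter and cAMP accumulation, with stated times of 15 min and 6 h (on this read-out higher numbers stand for weaker inhibition and lower numbers for stronger inhibition), where compound 2 gives 3160 nM. Among the two numbers reported, compound 2 stands highest; its nearest neighbour is compound 1 `Cc1ccc(-c2nc(N)c3cc(Cc4ccccc4Cl)sc3n2)o1`, which in this assay gives 26.1 nM, a gap that lies beyond the usual scatter. Compound 3 `C=C(c1ccccc1)c1cc2c(N)nc(-c3cccc(C#N)c3)nc2s1` is reported in this assay as > 1000 nM, which is a limit of the assay and not a number. That reading for compound 3 is the limit of > 1000 nM in this assay, at which 1 of the 3 values shown sits.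

Compound 4 `Nc1nc(-c2ncccn2)nc2sc(Cc3ccccc3)cc12` differs from compound 2 in one place: pyrimidin-2-yl in place of 5-cyanofuran-2-yl on an aromatic carbon. For the measured compounds named here, no measured pair in this set separates the 5-cyanofuran-2-yl group from the pyrimidin-2-yl group, so the size of the step rests on expectation alone. Compound 4 is expected to fall lower than compound 2 by a step of an 11-fold lower number from compound 2 to compound 4 (1.02 log units; beyond the scatter), beyond the scatter, since compound 2 with its 3160 nM sits well above compound 1. Compound 4 is therefore estimated at 300 nM, with a range from 50 nM to 2000 nM.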

Compound 4, inhibition constant: 618 nM
The estimate for compound 4 lay 2.1-fold (0.31 log units) below the measured number; measured number inside the range.
By their numbers in this assay, from the lowest: compound 1; then compound 4; then compound 2.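

For the compounds shown here, replacing 5-cyanofuran-2-yl with pyrimidin-2-yl on the aromatic carbon between two ring nitrogen atoms gives a 5.1-fold lower number from compound 2 to compound 4 (0.71 log units; beyond the scatter) in this assay and is the first measured pair to isolate a change at this position. It shows that the read-out responds to the group carried here and that inhibition is stronger with a six-membered aromatic ring with 2 hetero atoms than with the nitrile-bearing five-membered ring. Nothing among the data shown accounts for this step.

The compounds shown leave open which part of the change carries the step, as they include neither a plain furan-2-yl nor a pyridin-2-yl at this position. Going by these compounds, it also remains open how an amine or a methoxy group on the pyrimidin-2-yl ring would read.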